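A Methyl Added to the Sulfonyl Phenyl Ring

The source may hold more compounds than are shown below. What is called first, only, known or untested is meant among the compounds shown, and "the series" means these compounds.

compound 1 `N#CN/C(=N\CCNC(=O)c1ccccc1[N+](=O)[O-])NCCCCOc1cccc(CN2CCCCC2)c1` — 7.52
compound 2 `N#CN/C(=N\CCCNC(=O)c1ccccc1)NCCCCOc1cccc(CN2CCCCC2)c1` — 6.6
compound 3 `N#CN/C(=N\CCNS(=O)(=O)c1ccccc1)NCCCCOc1cccc(CN2CCCCC2)c1` — 7.28

These three compounds share one core and were tested in a functional assay on cardiac atrium for antagonist activity at histamine H2 receptor (Cavia porcellus); a higher number here means a more potent compound, by a factor of ten per unit of this negative logarithm, a lower number a less potent compound. Compound 3 stands second highest of the three: its gap to compound 1, a number 0.24 log units lower from compound 1 to compound 3 (within the scatter), lies within the scatter, while the step of a number 0.68 log units higher from compound 2 to compound 3 (beyond the scatter) lies beyond it, as does a number 0.92 log units lower from compound 1 to compound 2 (beyond the scatter). Compound 4 `Cc1ccc(S(=O)(=O)NCC/N=C(\NC#N)NCCCCOc2cccc(CN3CCCCC3)c2)cc1` differs from compound 3 by methyl in place of hydrogen on an aromatic carbon, on an aromatic carbon of a six-membered aromatic ring of carbon only, para to a large group; phenylsulfonyl becomes (4-methylphenyl)sulfonyl. For the measured compounds named here, none of the measured steps bears on such a ring substituent — each alters the acyl or sulfonyl group itself or the chain that carries it — so nothing here supports a step beyond the scatter in this assay. The step of a number 0.02 log units higher from compound 3 to compound 4 (within the scatter) is therefore expected to stay within the scatter. Compound 4 is estimated at 7.3, between 6.8 and 7.8.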

Compound 4, negative logarithm of the antagonist equilibrium constant: 7.29
Estimate against measurement, compound 4: 0.01 log units above; low and high end bracket the measured number.
By their numbers in this assay, from the lowest: compound 2; then compounds 3, 4 and 1 (each within the scatter of the next).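

In this assay methyl in place of hydrogen on an aromatic carbon, para to a large group, gives a step of a number 0.01 log units higher from compound 3 to compound 4 (within the scatter) and so leaves no readable change at this position. Compound 4 also keeps the standing of compound 3, with a number 0.23 log units lower from compound 1 to compound 4 (within the scatter) and a number 0.69 log units higher from compound 2 to compound 4 (beyond the scatter) as its steps to the two amides. Nothing measured here gives a reason for this. As far as these compounds go, whether a methoxy group, an amine or a carboxylic acid in place of this methyl would move the number stays open.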